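Sulfonyl substituent swap in the shared core: aryl to morpholine

The source may hold more compounds than are shown below. What is called first, only, known or untested is meant among the compounds shown, and "the series" means these compounds.

Compound 2 `Cc1c(Cc2ccccc2S(=O)(=O)c2ccc(OC(F)(F)F)cc2)c2c(n1CC(=O)O)CCNC2=O` carries a 4-(trifluoromethoxy)phenyl on the sulfonyl sulfur. Going by the values given here, in a functional assay on CHO.K1 cells for antagonist activity at prostaglandin D2 receptor 2 (Homo sapiens), read by GTPgammaS binding, with a stated time of 1 h (on this read-out lower numbers stand for stronger inhibition and higher numbers for weaker inhibition), compound 2 gives 6.6 nM, the highest of the two numbers so far, with compound 1 `Cc1c(Cc2ccccc2S(=O)(=O)c2cccc(Cl)c2)c2c(n1CC(=O)O)CCNC2=O` nearest; in this assay compound 1 gives 4 nM. Among the compounds with values here, the only measured step, a 1.7-fold higher number from compound 1 to compound 2 (0.22 log units; within the scatter), exchanges one six-membered aromatic ring of carbon only for another on that sulfur and stays within the scatter.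

Compound 3 `Cc1c(Cc2ccccc2S(=O)(=O)N2CCOCC2)c2c(n1CC(=O)O)CCNC2=O` differs from compound 2 by morpholin-4-yl in place of 4-(trifluoromethoxy)phenyl on a sulfonyl sulfur. Within the data shown here, no measured step covers an exchange of an aromatic ring for a six-membered non-aromatic ring with 2 hetero atoms at this position, so the aryl-to-aryl step gives little guidance. The expectation for compound 3 is therefore a number near that of compound 2, with wide uncertainty, leaning toward a somewhat higher number in this assay: the expected step is a 2.3-fold higher number from compound 2 to compound 3 (0.36 log units; beyond the scatter). The estimate for compound 3 is 15 nM, in the range 4 nM to 60 nM.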

Compound 3, half-maximal inhibitory concentration: 22 nM
Estimate against measurement, compound 3: 1.5-fold (0.17 log units) below, and the stated range covers the measured number.
By their numbers in this assay, from the lowest: compounds 1 and 2 (each within the scatter of the next); then compound 3.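

Morpholin-4-yl in place of an aryl group is the first change on the sulfonyl sulfur to move the number beyond the scatter in this assay, with a 3.3-fold higher number from compound 2 to compound 3 (0.52 log units; beyond the scatter) and a 5.5-fold higher number from compound 1 to compound 3 (0.74 log units; beyond the scatter) both read as modest. Both steps point the same way, whereas the aryl-to-aryl step stayed within the scatter, so at this position the exchange of an aromatic ring for this non-aromatic ring registers where the exchange of one aryl group for another did not. Compound 3 still gives 22 nM, so an aromatic ring on the sulfur is not required for inhibition in the nanomolar range. No measured evidence accounts for the higher number.

Going by these compounds, whether the higher number goes with the loss of the aromatic ring in general or with morpholin-4-yl in particular remains open. A piperidin-1-yl, a 4-methylpiperazin-1-yl or an open-chain diethylamino group on the sulfonyl sulfur would separate these two readings.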